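Swapping the Ring Substituent on a Migration-Inhibiting Coumarin Ester

A few compounds are considered here, and "the series" means these few. Any claim that something is new, unique, unknown or untested is made for them only; others in the source may bear on it.

Compound 1 `CC(=O)OCc1ccc2oc(=O)c(C(=O)Oc3cccc(Cl)c3)cc2c1`: 49.1%
Compound 2 `CC(=O)OCc1ccc2oc(=O)c(C(=O)Sc3ccccc3)cc2c1`: 83.5%
Compound 3 `CC(=O)OCc1ccc2oc(=O)c(C(=O)Nc3cccc(Cl)c3)cc2c1`: 66.9%

In a functional assay on HT-1080 cells (Homo sapiens), read by transwell migration, with a stated time of 24 h, tested at 1 uM (a higher number here means a weaker effect of the compound at the concentration tested, a lower number a stronger effect), compound 1 gives 49.1%, the lowest of the three numbers; compound 3 lies a number 17.8 percentage points higher from compound 1 to compound 3 (beyond the scatter) and compound 2 a number 34.4 percentage points higher from compound 1 to compound 2 (beyond the scatter). Compound 4 `O=C(Oc1cccc(Cl)c1)c1cc2cc([N+](=O)[O-])ccc2oc1=O` differs from compound 1 by nitro in place of acetoxymethyl on an aromatic carbon. Every measured step, including a number 16.6 percentage points lower from compound 2 to compound 3 (beyond the scatter), changes the group on the carbonyl carbon, not the substituent on the fused aromatic ring, so none bears directly on this change. With no guide, a step of no clear size beyond the scatter in either direction is expected for compound 4 in this assay , a number 0.9 percentage points higher from compound 1 to compound 4 (within the scatter). Compound 4 is therefore estimated at 50%, within 28% to 75%.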

Compound 4, a percentage reported as activity, at one concentration (the size of the read-out at that concentration, not a potency): 65.8%
Estimate against measurement, compound 4: 15.8 percentage points below; measured number inside the range.
By their numbers in this assay, from the lowest: compound 1; then compounds 4 and 3 (each within the scatter of the next); then compound 2.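

In this assay, with the 3-chlorophenoxy group on the carbonyl carbon held fixed, nitro in place of acetoxymethyl on the aromatic carbon gives a number 16.7 percentage points higher from compound 1 to compound 4 (beyond the scatter). This is the first step shown at this position, and it shows that the read-out responds to the substituent on the fused aromatic ring, not only to the group on the carbonyl carbon. Nothing available accounts for the size or direction of this step. As far as these compounds go, whether an amine or a hydroxymethyl group at this carbon would match acetoxymethyl remains open. So does whether the step would recur with phenylsulfanyl or (3-chlorophenyl)amino on the carbonyl carbon.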